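The source may report more compounds than this note shows. Statements on the series, on what has been measured and on what is new or still open speak of the compounds shown alone.

Measured so far:
compound 1, `Cn1nnc2cc(C(N)=O)ccc2c1=O`: 380000 nM
compound 3, `NC(=O)c1cccc2c(O)nnnc12`: 400000 nM
compound 2, `Cn1nnc2c(C(N)=O)cccc2c1=O`: > 500000 nM, a limit of the assay, not a number

In a functional assay on TLX-5 cells (Mus musculus) for cytotoxicity (a lower number here means a stronger inhibitor, a higher number a weaker inhibitor), compound 1 gives 380000 nM, the lowest of the two numbers shown. Compound 3 gives 400000 nM, within the scatter of compound 1, so no order between the two can be read. Compound 2 sits at the limit of > 500000 nM in this assay, at which 1 of the 3 values shown sits.

Compound 4, `NC(=O)c1ccc2c(=O)n(-c3ccccc3)nnc2c1`, is not yet measured. It differs from compound 1 by phenyl in place of methyl on an aromatic nitrogen. For the measured compounds named here, no measured pair shows this change, so no size of step in this assay can be taken from the data. Compound 4 is expected to stay in the same weak range, with the step of a 1.5-fold lower number from compound 1 to compound 4 (0.18 log units; within the scatter) small and of uncertain direction. The estimate for compound 4 is 250000 nM, between 60000 nM and 600000 nM.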

Compound 4, half-maximal inhibitory concentration: 140000 nM
For compound 4 the middle estimate is 1.8-fold (0.25 log units) above the measured one; low and high end bracket the measured number.
By their numbers in this assay, from the lowest: compound 4; then compounds 1 and 3 (each within the scatter of the next). At a limit, above all of these: compound 2.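

In this assay, for the compounds shown here, phenyl in place of methyl on the aromatic nitrogen gives a 2.7-fold lower number from compound 1 to compound 4 (0.43 log units; beyond the scatter), the first step that can be read and one that lies beyond the scatter. This position therefore tolerates an aromatic ring without loss, although compound 4 remains weak at 140000 nM. Nothing shown gives a cause for this step.

A single pair cannot separate the effect of the aromatic ring from that of a larger group. Open on this nitrogen are a benzyl group, a longer chain such as butyl, and a phenyl carrying an amine.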